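The source may hold more compounds than are shown below. What is called first, only, known or untested is meant among the compounds shown, and "the series" means these compounds.

Within the data shown here, compound 1, with the structure `CCOC(=O)/C(=N\O)c1ccc(Sc2cc(F)cc(C3CCOCC3)c2)cc1`, is one of two compounds measured so far in a functional assay (blood) for inhibition, with Homo sapiens as the target; on this read-out lower numbers stand for stronger inhibition and higher numbers for weaker inhibition. In that assay compound 1 gives 170 nM, the highest of the two numbers recorded. Compound 2, with the structure `CO[C@]1(c2cc(F)cc(Sc3ccc(/C(C)=N/O)cc3)c2)CCO[C@@H](C)C1`, gives 40 nM in this assay; the two values differ by more than the usual scatter of repeated measurements, and the two compounds differ from each other in more than one place, so nothing more than the bare comparison of the two values is drawn from them.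

Compound 3, with the structure `C/C(=N\OC(=O)N(C)C)c1ccc(Sc2cc(F)cc(C3CCOCC3)c2)cc1`, has not yet been measured in this assay. It differs from compound 1 in one place: a group of 9 heavy atoms (5 carbon, 2 nitrogen, 2 oxygen; no ring) in place of a group of 8 heavy atoms (4 carbon, 1 nitrogen, 3 oxygen; no ring), on an aromatic carbon. Compound 1 carries the group with the hydrogen-bond donor; compound 3 carries the group without one.

Among the measured compounds shown here, with no pair of measured compounds that differ in only one place, there is no step of this kind to lean on. The step from compound 1 to compound 3 is expected to be modest, a 1.9-fold lower number from compound 1 to compound 3 (0.28 log units; within the scatter), toward a lower number and possibly no larger than the scatter. Compound 3 is therefore expected to give about 90 nM in this assay, most likely between 30 nM and 300 nM.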

Compound 3, half-maximal inhibitory concentration: 2610 nM
The estimate for compound 3 lay 29-fold (1.46 log units) below the measured number, outside the stated range (above it).
By their numbers in this assay, from the lowest: compound 2; then compound 1; then compound 3.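

In this assay the position on an aromatic carbon of a six-membered aromatic ring of carbon only, para to a large group, proves sensitive to the group it carries: the group of 9 heavy atoms (5 carbon, 2 nitrogen, 2 oxygen; no ring) in place of the group of 8 heavy atoms (4 carbon, 1 nitrogen, 3 oxygen; no ring) gives a large step (a 15-fold higher number from compound 1 to compound 3 (1.19 log units; beyond the scatter)) with the rest of the structure unchanged. Among these compounds, this is the first comparison in which only one place differs, and here the group without a hydrogen-bond donor goes with much weaker inhibition, although this single pair cannot separate the donor from the other differences between the two groups. No measurement of any property of these groups bears on the size of this step.

The compounds shown leave open which part of the entering group goes with the loss, and whether the donor alone accounts for it. They also leave open how an amine, a carboxylic acid or a longer alkyl chain would read out at this position on the core of compound 1.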